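The source may hold more compounds than are shown below. What is called first, only, known or untested is meant among the compounds shown, and "the series" means these compounds.

Of the compounds shown here, three have been tested so far in a functional assay on SW-620 cells (Homo sapiens) for inhibition, read by MTT assay, with a stated time of 72 h; on this read-out lower numbers stand for stronger inhibition of growth and higher numbers for weaker inhibition of growth. Compound 1 (`Cc1nn(C)cc1-c1nc2c(N3CCN(Cc4ncn(C)n4)CC3)c(Cl)cnc2[nH]1`) gives 3140 nM, compound 2 (`Cc1cc(CN2CCN(c3c(Cl)cnc4[nH]c(-c5ccn(C)n5)nc34)CC2)no1`) gives 2600 nM, and compound 3 (`Cc1nn(C)cc1-c1nc2c(N3CCN(Cc4cnccn4)CC3)c(Cl)cnc2[nH]1`) gives 1090 nM. Compound 3 has the lowest number of the three, and its gaps to the other two lie beyond the usual scatter.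

Compound 4 (`Cc1nn(C)cc1-c1nc2c(N3CCN(Cc4nonc4C)CC3)c(Cl)cnc2[nH]1`) keeps everything in compound 3 except the group on a saturated chain carbon bound to an amine nitrogen in a ring: 4-methyl-1,2,5-oxadiazol-3-yl in place of pyrazin-2-yl on a saturated chain carbon bound to an amine nitrogen in a ring. In words, 4-methyl-1,2,5-oxadiazol-3-yl takes the place of pyrazin-2-yl, so a five-membered aromatic ring replaces a six-membered one.

Going by the values given here, only one measured step changes this group alone: a 2.9-fold lower number from compound 1 to compound 3 (0.46 log units; beyond the scatter), where pyrazin-2-yl replaced 1-methyl-1H-1,2,4-triazol-3-yl. That step is modest. Compound 2 also has a five-membered ring here and gives 2600 nM, but it differs from compound 3 in more than one place, so it is only weak support. Among the compounds with values here, no tested compound carries the new group, so this is a comparison by ring size alone.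

A modest move to a higher number is therefore expected, roughly the size of the triazole step in reverse: a 2.1-fold higher number from compound 3 to compound 4 (0.32 log units; beyond the scatter). The estimated value for compound 4 is 2300 nM, with an expected range of 1000 nM to 5000 nM.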

Compound 4, concentration for 50% growth inhibition: 250 nM
Compound 4: middle estimate off by 9.2-fold (0.96 log units), on the high side, outside the stated range (below it).
By their numbers in this assay, from the lowest: compound 4; then compound 3; then compounds 2 and 1 (each within the scatter of the next).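

In this assay, going by these compounds alone, the position on a saturated chain carbon bound to an amine nitrogen in a ring proves more responsive than the earlier compounds showed, with a 4.4-fold lower number from compound 3 to compound 4 (0.64 log units; beyond the scatter) and, against the triazole, a 13-fold lower number from compound 1 to compound 4 (1.10 log units; beyond the scatter). Ring size alone does not set the order: compound 1 and compound 4 both carry a five-membered aromatic ring here, yet they lie at opposite ends of this series, and compound 3, with its six-membered ring, falls between them. The swap from pyrazin-2-yl to 4-methyl-1,2,5-oxadiazol-3-yl keeps the count of heavy atoms the same while changing the ring atoms, so the gain cannot be tied to a larger group, and nothing available accounts for why this ring gives the lowest number.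

On these data alone, the role of the methyl group stays open, as the comparison offers no unsubstituted 1,2,5-oxadiazol-3-yl ring to set beside compound 4. Also open, as far as these compounds go, is how a plain phenyl ring, an isoxazole on the same core or an open chain such as a methoxyethyl group would behave at this position.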